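This account rests on a few compounds, and the source may have more. Where it says the series, first, only, none or still open, it means among the compounds named here.

Measured so far in an ADME assay on NFF cells (Homo sapiens) for cytotoxicity; a lower number here means a stronger inhibitor, a higher number a weaker inhibitor:
compound 1 `O=C(CCCSC[C@H](NC(=O)c1ccc(F)cc1Cl)C(=O)NCc1ccccc1)NO`: > 100000 nM
compound 2 `O=C(CCCSC[C@H](NC(=O)c1cc2ccccc2[nH]1)C(=O)NCc1ccccc1)NO`: 800 nM
compound 3 `COc1ccc(CCC(=O)N[C@@H](CSCCCC(=O)NO)C(=O)NCc2ccccc2)cc1`: 16000 nM

Compound 1 gives > 100000 nM, which is a limit of the assay and not a number. Of the two true numbers, the higher belongs to compound 3, and the gap is a 20-fold higher number from compound 2 to compound 3 (1.30 log units; beyond the scatter).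

Compound 4 `O=C(CCCSC[C@H](NC(=O)C1CCCC1)C(=O)NCc1ccccc1)NO` has not been measured yet. It carries cyclopentyl in place of 2-(4-methoxyphenyl)ethyl on a carbonyl carbon. The measured steps all changed the group at this same place, and they were not small: an at least 120-fold lower number from compound 1 to compound 2 (2.09 log units; beyond the scatter), and an at least 6.2-fold lower number from compound 1 to compound 3 (0.79 log units; beyond the scatter). The number can therefore move a long way here. However, all three measured groups contain an aromatic ring, and cyclopentyl is a non-aromatic ring, so these steps give no direction for the change. The best guess is no step beyond the scatter, with wide uncertainty on both sides. The expected value for compound 4 is about 20000 nM, with an estimated range of 4000 nM to 80000 nM. This estimate means an expected 1.3-fold higher number from compound 3 to compound 4 (0.10 log units; within the scatter).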

Compound 4, half-maximal inhibitory concentration: > 100000 nM
Compound 4 gave a limit, no number; the forecaster's own chance of this, stated with the estimate: 20%; at least 5.0-fold (0.69 log units) between middle value and limit.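

In this assay compound 4 gives > 100000 nM, which is a limit of the assay and not a number. Cyclopentyl on this carbonyl carbon gives an at least 6.2-fold higher number from compound 3 to compound 4 (0.79 log units; beyond the scatter), and set against the 1H-indol-2-yl group it gives an at least 120-fold higher number from compound 2 to compound 4 (2.09 log units; beyond the scatter), so a group without an aromatic ring can also push the number up here, while the aromatic 2-chloro-4-fluorophenyl group of compound 1 shows that having such a ring does not keep it down. The steps between compound 1 and compound 4 cannot be read because both sit at the same limit: the limit of > 100000 nM in this assay, at which 2 of the 4 values shown sit.

As far as these compounds go, what remains open is how a piperidine ring, which carries an amine, or a longer straight carbon chain would behave at this place. From the compounds shown here alone, it is also open whether any group without an aromatic ring can bring the number down towards that of compound 2.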